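Removing the Methyl from the Ether Oxygen of Compound 3

This account rests on a few compounds, and the source may have more. Where it says the series, first, only, none or still open, it means among the compounds named here.

Compound 1, `CSC(=O)c1c(C)c(C)c(O)c(C)c1O[C@@H]1O[C@H](CO)[C@@H](O)[C@H](O)[C@H]1O`, gives > 40000 nM in a functional assay on MDA-MB-231 cells (Homo sapiens) for cytotoxicity, read by sulforhodamine B assay, with a stated time of 72 h (on this read-out lower numbers stand for stronger inhibition and higher numbers for weaker inhibition), a limit of the assay rather than a number.
Compound 2, `CSC(=O)c1c(O[C@@H]2O[C@H](COC(C)=O)[C@@H](O)[C@H](O)[C@H]2O)c(C)c(O)c(C)c1C(C)C`, gives > 40000 nM in this assay, also a limit.
Compound 3, `COc1c(C)c(O)c(C)c(C(C)C)c1C(=O)SC`, gives 36000 nM in this assay.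

Compound 3 thus stands as the only one of the three with a measured number; the other two sit at a limit. Compound 4, `CSC(=O)c1c(O)c(C)c(O)c(C)c1C(C)C`, differs from compound 3 by hydrogen in place of methyl on an oxygen on an aromatic ring. Among the compounds with values here, no measured pair here differs in one place, so no step of this kind is known. The change is expected to move this assay by no more than the scatter, leaning toward weaker because the limit of > 40000 nM in this assay, at which 2 of the 3 values shown sit, holds two of the three values shown. The expected step is a 1.1-fold higher number from compound 3 to compound 4 (0.05 log units; within the scatter). Compound 4 is expected to give about 40000 nM, within 13000 nM to 120000 nM.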

Compound 4, half-maximal inhibitory concentration: > 40000 nM
Compound 4: only a limit was reported; the forecaster's own chance of this, stated with the estimate: 50%; the middle value sits exactly at the limit.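

Within the data shown here, the first direct comparison at this oxygen, methoxy to hydroxy, reads in this assay as an at least 1.1-fold higher number from compound 3 to compound 4 (0.04 log units; that floor lies within the scatter). Compound 4 gives > 40000 nM, which is a limit of the assay and not a number. Replacing the methyl with hydrogen on this oxygen therefore brings no measurable gain here, and the true size of the step stays unknown: the limit of > 40000 nM in this assay, at which 3 of the 4 values shown sit.

As far as these compounds go, what an ethoxy group or an amine in place of the methoxy would do stays open. So does whether any change at this oxygen can give a stronger number than compound 3 gives.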